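The compounds below may be only part of what the source reports. "The series", "measured", "known", "first", "only" and "open" are said of these compounds alone.

Of the compounds shown here, three have been measured in an ADME assay on Vero cells (Chlorocebus sabaeus) for cytotoxicity, read by MTT assay, with a stated time of 72 h; on this read-out higher numbers stand for lower toxicity in this test and lower numbers for higher toxicity in this test: compound 1 `CCCCNc1nc(NCCCCOc2nc(NCCCC)nc(Nc3ccccc3)n2)nc(Nc2ccccc2)n1`, compound 2 `CCCNc1nc(NCCCCOc2nc(NCCC)nc(Nc3ccccc3)n2)nc(Nc2ccccc2)n1` and compound 3 `c1ccc(Nc2nc(NCCCCOc3nc(Nc4ccccc4)nc(N4CCc5ccccc5C4)n3)nc(N3CCc4ccccc4C3)n2)cc1`. Compound 1 gives > 400000 nM, which is a limit of the assay and not a number. Compound 3 gives > 400000 nM, which is likewise a limit. Among the compounds with values here, compound 2 gives 216000 nM, the only true number among the three, so it is the one firm reference point in this assay.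

Compound 4 `CCCNc1nc(Nc2ccccc2)nc(OCCCCNc2nc(Nc3ccccc3)nc(NC3CC3)n2)n1` is built from compound 2 by a single edit, with cyclopropyl in place of propyl on a nitrogen on an aromatic ring. Read one bond further out, this is propylamino to cyclopropylamino, and the rest of the structure stays the same. Within the data shown here, no measured pair here shows this change on its own, so there is no direct precedent for its size. With compound 2 at 216000 nM as the only numerical anchor, no shift beyond the usual scatter is expected, in either direction. The expected change is a 1.0-fold higher number from compound 2 to compound 4 (0.01 log units; within the scatter), and it amounts to no real difference. The estimated value for compound 4 is 220000 nM, with an expected range from 100000 nM to 400000 nM.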

Compound 4, half-maximal cytotoxic concentration: > 400000 nM
Compound 4 ended at the assay's limit (the forecaster's own chance of this, stated with the estimate: 25%); middle value at least 1.8-fold (0.25 log units) away from the limit.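

In this assay compound 4 gives > 400000 nM, which is a limit of the assay and not a number. Putting cyclopropyl in place of propyl on a nitrogen on an aromatic ring is the only single-place change among the compounds shown, and it reads as an at least 1.8-fold higher number from compound 2 to compound 4 (0.26 log units; that floor lies within the scatter), so this swap gave no sign of a lower number, while the true size of the step stays unknown and its floor cannot be called a real difference. The result also shows how little room this read-out leaves for telling such compounds apart: the limit of > 400000 nM in this assay, at which 3 of the 4 values shown sit.

From the compounds shown here alone, it remains open whether cyclopropyl matters in particular or whether most small groups on this nitrogen would end at the same limit, and the second propyl of compound 4 leaves the effect of the same swap at that other place unknown as well. A longer chain such as hexyl, an amine-bearing chain such as dimethylaminoethyl, or a chain ending in a carboxylic acid at this position could show whether any change here brings the number down to a value that can be measured.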